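Working notes: thiophen-3-yl in place of furan-2-yl

This account rests on a few compounds, and the source may have more. Where it says the series, first, only, none or still open, it means among the compounds named here.

Measured so far in a functional assay on HL-60 cells (Homo sapiens) for antiproliferative activity, read by XTT assay, with a stated time of 72 h; a lower number here means a stronger inhibitor, a higher number a weaker inhibitor:
compound 1 `Cc1nc(N)c2c(-c3ccco3)cn([C@@H]3O[C@H](CO)[C@@H](O)[C@H]3O)c2n1`: > 20000 nM
compound 2 `C#Cc1cn([C@@H]2O[C@H](CO)[C@@H](O)[C@H]2O)c2ncnc(NC)c12`: 9060 nM
compound 3 `CNc1ncnc2c1c(I)cn2[C@@H]1O[C@H](CO)[C@@H](O)[C@H]1O`: > 20000 nM

The value of compound 1 in this assay is a limit, not a number. Compound 3 also stops at a limit, (the limit of > 20000 nM in this assay, at which 2 of the 3 values shown sit). Within the data shown here, only compound 2 gives a number, and the single measured step, an at least 2.2-fold higher number from compound 2 to compound 3 (0.34 log units; beyond the scatter), concerns iodo in place of ethynyl on compounds that do not share the pattern of compound 1.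

Compound 4 `Cc1nc(N)c2c(-c3ccsc3)cn([C@@H]3O[C@H](CO)[C@@H](O)[C@H]3O)c2n1` differs from compound 1 by thiophen-3-yl in place of furan-2-yl on an aromatic carbon. No measured step touches this change, so nothing shown argues for a move beyond the scatter in either direction. Compound 4 is therefore expected to stay near where compound 1 sits, a step of a number no higher from compound 1 to compound 4 (the limit leaves the size open), most likely again as a limit, with an estimate of 20000 nM (range 6000 nM to 60000 nM).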

Compound 4, half-maximal inhibitory concentration: > 20000 nM
Compound 4 gave a limit, no number; the forecaster's own chance of this, stated with the estimate: 65%; the middle value lies on the limit itself.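

In this assay compound 1 and compound 4 both end at a limit, so no step can be read between them: the limit of > 20000 nM in this assay, at which 3 of the 4 values shown sit. On these data alone, how thiophen-3-yl compares with furan-2-yl on the shared core remains open.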